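From Methyl to 4-Chlorophenyl: an Expected Step for Compound 4

The compounds below may be only part of what the source reports. "The series", "measured", "known", "first", "only" and "open" are said of these compounds alone.

Of the compounds shown here, three have been measured in a functional assay on the whole organism (strain albino) for inhibition, with Rattus norvegicus as the target, read by paw edema, with stated times of 3 h and 1 h, at a dose of 100 mg/kg by the oral route; on this read-out lower numbers stand for less inhibition and higher numbers for more inhibition at the one dose given (going by the name of the read-out). Compound 1 `Cc1cccc(NC(=S)NNC(=O)Cn2nc(C)cc2C)c1` gives 40.8% in this assay, and compound 2 `COc1ccc(NC(=S)NNC(=O)Cn2nc(C)cc2C)cc1` gives 46.4%. Compound 3 `Cc1cc(C)n(Cc2nnc(Nc3ccc([N+](=O)[O-])cc3)s2)n1` gives 64.9%, the highest of the three numbers, and its margin over compound 2 as well as over compound 1 lies beyond the usual scatter. Compound 4 `Cc1cc(-c2ccc(Cl)cc2)n(Cc2nnc(Nc3ccc([N+](=O)[O-])cc3)s2)n1` has not been measured. It differs from compound 3 in one place: 4-chlorophenyl in place of methyl on an aromatic carbon. Within the data shown here, no measured pair differing in only one place exists here, so the direction of this exchange has no precedent among the three. The expected step of a number 1.1 percentage points higher from compound 3 to compound 4 (within the scatter) is small, not beyond the scatter. Compound 4 is estimated at 66%, with a range from 50% to 80%.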

Compound 4, a percentage reported as inhibition, in the whole organism at one dose (the size of the read-out at that dose, not a potency): 61.1%
Compound 4: middle estimate off by 4.9 percentage points, on the high side, within the range that was stated.
By their numbers in this assay, from the lowest: compounds 1 and 2 (each within the scatter of the next); then compounds 4 and 3 (each within the scatter of the next).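

In this assay, among these compounds, putting 4-chlorophenyl in place of methyl on this aromatic carbon gives a number 3.8 percentage points lower from compound 3 to compound 4 (within the scatter), the first single-place comparison in this set. This position therefore accepts a much larger group, with one six-membered aromatic ring, without a change in the read-out beyond the scatter. Nothing available explains this result.

As far as these compounds go, what remains open is whether a plain phenyl without the chlorine would behave the same way. An amine, a carboxylic acid or a longer chain at this position is also untested here.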